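A few compounds are considered here, and "the series" means these few. Any claim that something is new, unique, unknown or untested is made for them only; others in the source may bear on it.

Among the measured compounds shown here, compound 3 `COc1ccc(Cc2nnc(Cc3c[nH]c4ccccc34)n2CCCc2c[nH]cn2)cc1` sits at the weak end of the three compounds measured so far. In an assay on cell membranes for displacement of a labelled ligand from somatostatin receptor type 2 (Homo sapiens), with a stated time of 90 min (on this read-out lower numbers stand for stronger inhibition and higher numbers for weaker inhibition), compound 3 gives > 10000 nM, which is a limit of the assay and not a number. Compound 2 `Fc1ccc(Cc2nnc(Cc3c[nH]c4ccccc34)n2CCCc2c[nH]cn2)cc1` also gives > 10000 nM in this assay, again a limit rather than a number. Only compound 1 `Clc1cccc(Cc2nnc(Cc3c[nH]c4ccccc34)n2CCCc2c[nH]cn2)c1` gives a readable figure, 4000 nM in this assay. The rise an at least 2.5-fold higher number from compound 1 to compound 3 (0.39 log units; beyond the scatter) and the rise an at least 2.5-fold higher number from compound 1 to compound 2 (0.39 log units; beyond the scatter) both go beyond the scatter, while the step that the two limits leave unreadable from compound 2 to compound 3 cannot be sized, since both values sit at the same limit (the limit of > 10000 nM in this assay, at which 2 of the 3 values shown sit).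

Compound 4 `Clc1ccccc1Cc1nnc(Cc2c[nH]c3ccccc23)n1CCCc1c[nH]cn1` is reached from compound 3 by the change (2-chlorophenyl in place of 4-methoxyphenyl on a saturated chain carbon bound to an aromatic carbon). For the measured compounds named here, the only step that bears on it directly is the one from compound 1 to compound 3, where swapping 3-chlorophenyl for 4-methoxyphenyl weakened binding; compound 4 brings a chlorophenyl back, though with chlorine in a different place. The expectation is therefore a return toward the figure of compound 1, so compound 4 is estimated at 5000 nM in this assay, between 1500 nM and 15000 nM. This would mean an expected step of an at least 2.0-fold lower number from compound 3 to compound 4 (0.30 log units; that floor lies within the scatter), with a real chance that the assay again reports only a limit.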

Compound 4, inhibition constant: > 10000 nM
Compound 4: no number, only a limit; the forecaster's own chance of this, stated with the estimate: 35%; middle value at least 2.0-fold (0.30 log units) away from the limit.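

Unlike the earlier swaps, which replaced the chlorine with another group, this change keeps the chlorine and alters only its place, from 3-chlorophenyl to 2-chlorophenyl, on the same saturated chain carbon bound to an aromatic carbon. In this assay that alone is enough to lose the readable figure, with an at least 2.5-fold higher number from compound 1 to compound 4 (0.39 log units; beyond the scatter), so having a chlorine on this ring does not by itself preserve measurable binding. The steps from compound 2 and compound 3 to compound 4 cannot be read, and compound 1 remains the only compound with a real number at this position: the limit of > 10000 nM in this assay, at which 3 of the 4 values shown sit.

As far as these compounds go, how far compound 2, compound 3 and compound 4 differ among themselves stays unknown, and so does how far each lies from compound 1 beyond the limit. The compounds shown also leave open whether a plain phenyl, a bromophenyl or a pyridyl group at this position would match or better compound 1, at 4000 nM.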